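Fluoro in place of trifluoromethyl on compound 3

The source may hold more compounds than are shown below. What is called first, only, known or untested is meant among the compounds shown, and "the series" means these compounds.

Values in a functional assay on HeLa cells (Homo sapiens) for antiproliferative activity, read by MTT assay, with a stated time of 72 h (on this read-out lower numbers stand for stronger inhibition and higher numbers for weaker inhibition), so far:
- compound 1 `CCCNC(=O)c1cc(Oc2ccc(NC(=O)c3nn(-c4ccc(Br)cc4F)c(=O)cc3C)cc2F)ccn1` gives 53500 nM 
- compound 2 `CCCNC(=O)c1cc(Oc2ccc(NC(=O)c3nn(-c4ccccc4C)c(=O)cc3C)cc2F)ccn1` gives 24600 nM 
- compound 3 `CCCNC(=O)c1cc(Oc2ccc(NC(=O)c3nn(-c4cccc(C(F)(F)F)c4)c(=O)cc3C)cc2F)ccn1` gives 8000 nM 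

Compound 3 holds the lowest of the three numbers. Compound 4 `CCCNC(=O)c1cc(Oc2ccc(NC(=O)c3nn(-c4cccc(F)c4)c(=O)cc3C)cc2F)ccn1` differs from it by fluoro in place of trifluoromethyl on an aromatic carbon and is still to be measured. Among the compounds with values here, no measured pair makes this exact change. The nearest evidence is the swaps of the group on the aromatic nitrogen, a 6.7-fold lower number from compound 1 to compound 3 (0.83 log units; beyond the scatter) and a 3.1-fold lower number from compound 2 to compound 3 (0.49 log units; beyond the scatter), both modest. A modest move to a higher number is therefore expected in this assay, with a step in the other direction not excluded. The expected step is a 1.8-fold higher number from compound 3 to compound 4 (0.24 log units; within the scatter) in size. Compound 4 is expected near 14000 nM, with an estimated range of 5500 nM to 35000 nM.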

Compound 4, half-maximal inhibitory concentration: 6660 nM
Compound 4: middle estimate off by 2.1-fold (0.32 log units), on the high side; the measured number falls inside the stated range.
By their numbers in this assay, from the lowest: compounds 4 and 3 (each within the scatter of the next); then compound 2; then compound 1.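

In this assay, fluoro in place of trifluoromethyl on this aromatic carbon gives a 1.2-fold lower number from compound 3 to compound 4 (0.08 log units; within the scatter), so this position tolerates the drop from 4 heavy atoms to 1 without a readable change. The 3-fluorophenyl group also stands apart from the two other groups on the aromatic nitrogen, with a 3.7-fold lower number from compound 2 to compound 4 (0.57 log units; beyond the scatter) and an 8.0-fold lower number from compound 1 to compound 4 (0.90 log units; beyond the scatter). No measurement shown here accounts for these numbers. Open, on these data alone, is whether an amine or a carboxylic acid on this aromatic carbon would leave the number unchanged.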